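Swapping a hydroxy for iodo on the sugar arm

The source may report more compounds than this note shows. Statements on the series, on what has been measured and on what is new or still open speak of the compounds shown alone.

Compound 1, `Nc1nc(O)c2c(n1)n(C1OC(CO)[C@@H](O)[C@H]1O)c(=O)n2Cc1ccc(Cl)c(Cl)c1`: 0%
Compound 2, `Cn1c(=O)n(C2OC(CO)[C@@H](O)[C@H]2O)c2nc(N)nc(O)c21`: 100%
Compound 3, `Nc1nc(O)c2c(n1)n(C1OC(CO)[C@@H](O)[C@H]1O)c(=O)n2CCN1CCCCC1`: 0%

Of the compounds shown here, three sharing one core have been tested in a functional assay on the whole organism with Mus musculus as the target; on this read-out lower numbers stand for smaller maximal responses and higher numbers for larger maximal responses. Compound 2 stands highest of the three: the step of a number 100 percentage points higher from compound 1 to compound 2 (beyond the scatter) and the step of a number 100 percentage points lower from compound 2 to compound 3 (beyond the scatter) both lie beyond the scatter, while the step of no change at the digits printed from compound 1 to compound 3 (within the scatter) shows compound 1 and compound 3 giving the same response within the scatter.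

Compound 4, `Cn1c(=O)n(C2OC(CI)[C@@H](O)[C@H]2O)c2nc(N)nc(O)c21`, has not yet been measured. It differs from compound 2 as follows: iodo in place of hydroxy on a saturated chain carbon bound to a saturated ring carbon. Among the measured compounds shown here, none of the measured steps touches this place; every measured change sits on the saturated chain carbon bound to an aromatic nitrogen, not on the saturated chain carbon bound to a saturated ring carbon. What those steps do show is that a single change in this series can move the response across its whole span. For the measured compounds named here, with no step at the relevant place, the expected step of a number 55 percentage points lower from compound 2 to compound 4 (beyond the scatter) is therefore wide open in direction, and the estimate carries a broad range. Compound 4 is expected to give 45% in this assay, with a range from 0% to 100%.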

Compound 4, largest response reached (reported as maximal response), in percent of the reference or control that the assay uses: 4%
For compound 4 the middle estimate is 41 percentage points above the measured one; measured number inside the range.
By their numbers in this assay, from the lowest: compounds 1, 3 and 4 (each within the scatter of the next); then compound 2.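

In this assay, iodo in place of hydroxy on a saturated chain carbon bound to a saturated ring carbon gives a number 96 percentage points lower from compound 2 to compound 4 (beyond the scatter), so the response of compound 2 depends on this place as well. The earlier steps shown here could not show this, since all of them changed the saturated chain carbon bound to an aromatic nitrogen, and this result adds a second place where one change takes away nearly all of the response seen with compound 2. The change is also small in atom count, with one heavy atom leaving and one entering, although the hydroxy brings a hydrogen-bond donor and a hydrogen-bond acceptor and the iodo brings neither, and nothing here gives a reason for the drop.

A single replacement cannot tell whether the hydroxy is needed at this place or the iodo is what removes the response, and an amine, a methoxy or a fluoro on the same carbon would be needed to separate the two. As far as these compounds go, it also remains open how a longer chain at this place would behave, and whether a hydroxy-to-iodo swap means anything in compounds that carry a larger group on the saturated chain carbon bound to an aromatic nitrogen.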